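Swapping a Para Nitrile for Fluorine on a Hydrazone Series

This account rests on a few compounds, and the source may have more. Where it says the series, first, only, none or still open, it means among the compounds named here.

Measured compounds and their values:
compound 1, `CC(=O)C[C@H]1O[C@@H](On2cc(CN3C(=O)/C(=N\Nc4ccc(C#N)cc4)c4ccccc43)nn2)[C@H](OC(C)=O)[C@@H](OC(C)=O)[C@@H]1OC(C)=O`, in an ADME assay on Vero cells (Chlorocebus sabaeus) for cytotoxicity, read by fluorescence and resazurin assay, with a stated time of 3 days; on this read-out higher numbers stand for lower toxicity in this test and lower numbers for higher toxicity in this test: 75400 nM
compound 2, `CC(=O)C[C@H]1O[C@@H](On2cc(CN3C(=O)/C(=N\Nc4ccc(F)cc4)c4ccccc43)nn2)[C@H](OC(C)=O)[C@@H](OC(C)=O)[C@@H]1OC(C)=O`, in this assay: 68700 nM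
compound 3, `CC1(C)O[C@H]2O[C@H](Cn3cc(CN4C(=O)/C(=N\Nc5ccc(C#N)cc5)c5ccccc54)nn3)[C@H](O)[C@H]2O1`, in this assay: 105000 nM

Compounds 1 and 2 share a core and differ in a single spot: fluoro in place of cyano on an aromatic carbon. The effect of that change was a 1.1-fold lower number from compound 1 to compound 2 (0.04 log units; within the scatter), so the two sugar-bearing compounds are, for practical purposes, indistinguishable in this assay.

Compound 3 carries a different core from compound 1; how the two cores differ is not broken down here. Its value sits near those of compound 1 and compound 2, and all three numbers lie within the usual scatter of one another, so no ranking among them can be drawn.

Compound 4, `CC1(C)O[C@H]2O[C@H](Cn3cc(CN4C(=O)/C(=N\Nc5ccc(F)cc5)c5ccccc54)nn3)[C@H](O)[C@H]2O1`, has not yet been measured. It stands to compound 3 exactly as compound 2 stands to compound 1: the change is fluoro in place of cyano on an aromatic carbon, and the surroundings of the changed spot read the same in both pairs, so this is the same change made once more on the second core.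

On that basis the expected step is a 1.1-fold lower number from compound 3 to compound 4 (0.04 log units; within the scatter), because a 1.1-fold lower number from compound 1 to compound 2 (0.04 log units; within the scatter) stayed within the scatter when the same swap was made before. Compound 4 is therefore estimated at 95000 nM in this assay, most likely between 50000 nM and 190000 nM.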

Compound 4, half-maximal cytotoxic concentration: 83800 nM
Beside the measured number, compound 4's estimate is 1.1-fold (0.05 log units) above it; the measured number falls inside the stated range.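

Repeating the swap of nitrile for fluoro on the core of compound 3 gives a 1.3-fold lower number from compound 3 to compound 4 (0.10 log units; within the scatter) in this assay, which is no real change in this read-out. Set side by side, the two steps from the two cores do not differ: the same change on two cores in this assay, a 1.1-fold lower number (0.04 log units; within the scatter) from compound 1 to compound 2 and a 1.3-fold lower number (0.10 log units; within the scatter) from compound 3 to compound 4, 1.1-fold (0.06 log units) apart, within the scatter of two such steps.
Within these two matched pairs, the swap therefore behaves alike on both cores, leaving the number inside ordinary repeat variation each time, but this shows only that the change has no detectable effect here, not that a real effect of a given size carries from one core to another, and two pairs cannot speak for any further core.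

The compounds shown have only a nitrile or a fluorine on that aromatic carbon, so it remains open whether a larger change there, such as an amine or a carboxylic acid, would move the number beyond the scatter on either core. On these data alone, all the numbers also come from this assay alone, so how the swap behaves in any other kind of test remains open too.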